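Adding one more chain carbon to compound 3

A few compounds are considered here, and "the series" means these few. Any claim that something is new, unique, unknown or untested is made for them only; others in the source may bear on it.

compound 1 `CCCCOc1c(-c2cc(OC)c(OC)c(OC)c2)oc2ccccc2c1=O`: 8900 nM
compound 2 `CCCCCOc1c(-c2cc(OC)c(OC)c(OC)c2)oc2ccccc2c1=O`: 15400 nM
compound 3 `CCCCCCOc1c(-c2cc(OC)c(OC)c(OC)c2)oc2ccccc2c1=O`: 19600 nM

These values come from a functional assay on LNCaP cells (Homo sapiens) for antiproliferative activity, read by WST assay, with a stated time of 3 days; a lower number here means a stronger inhibitor, a higher number a weaker inhibitor. The three compounds share one core and differ only in the length of one saturated chain. The place of compound 3 among them is fixed by two comparisons: a 1.3-fold higher number from compound 2 to compound 3 (0.10 log units; within the scatter), and a 2.2-fold higher number from compound 1 to compound 3 (0.34 log units; beyond the scatter).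

The next compound, compound 4 `CCCCCCCOc1c(-c2cc(OC)c(OC)c(OC)c2)oc2ccccc2c1=O`, extends that chain once more: methyl in place of hydrogen on a saturated chain carbon, six bonds along the chain from an oxygen on an aromatic ring. The closest guides are the two earlier single-carbon extensions: a 1.7-fold higher number from compound 1 to compound 2 (0.24 log units; within the scatter), and a 1.3-fold higher number from compound 2 to compound 3 (0.10 log units; within the scatter). Neither single extension left the scatter; only the two taken together did. One further extension is therefore not expected to give a step beyond the scatter in this assay, though a small move toward a higher number would continue the trend seen so far. The estimated change is a 1.2-fold higher number from compound 3 to compound 4 (0.07 log units; within the scatter). For compound 4, the expected value is 23000 nM, with an estimated range of 12000 nM to 42000 nM.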

Compound 4, half-maximal inhibitory concentration: > 50000 nM
Compound 4: no number, only a limit; the forecaster's own chance of this, stated with the estimate: 10%; middle value at least 2.1-fold (0.33 log units) away from the limit.
By their numbers in this assay, from the lowest: compounds 1, 2 and 3 (each within the scatter of the next, the first and the last beyond it). At a limit, above all of these: compound 4.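

In this assay compound 4 gives > 50000 nM, which is a limit of the assay and not a number. Adding methyl at this place, six bonds along the chain from an oxygen on an aromatic ring, gives the only single-carbon step beyond the scatter, an at least 2.5-fold higher number from compound 3 to compound 4 (0.40 log units; beyond the scatter), and the wider comparisons read an at least 3.2-fold higher number from compound 2 to compound 4 (0.51 log units; beyond the scatter) and an at least 5.6-fold higher number from compound 1 to compound 4 (0.74 log units; beyond the scatter). So lengthening the chain now clearly raises the number, but whether this step is truly larger than the same change made earlier cannot be decided: the same change on two cores in this assay, a 1.7-fold higher number (0.24 log units; within the scatter) from compound 1 to compound 2 and an at least 2.5-fold higher number (0.40 log units; beyond the scatter) from compound 3 to compound 4; the limit leaves it open whether they differ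

Going by these compounds, how far compound 4 truly lies from the other compounds stays open. Also open, on these data alone, is whether a longer chain, or an amine or a carboxylic acid in place of this methyl, would give a measurable number.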